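Swapping the Sulfonyl Aryl Group in Compound 2

The compounds below may be only part of what the source reports. "The series", "measured", "known", "first", "only" and "open" are said of these compounds alone.

Measured compounds:
- compound 1, `CC1CCN(c2c(S(=O)(=O)c3cc(Cl)cc(Cl)c3)cnc3ccc(Cl)cc23)CC1`, in an assay on isolated protein for displacement of a labelled ligand from metabotropic glutamate receptor 5 (Homo sapiens), with a stated time of 60 min, tested at 1 uM (on this read-out lower numbers stand for less inhibition and higher numbers for more inhibition at the one concentration tested (going by the name of the read-out)), gives 88%
- compound 2, `CC1CCN(c2c(S(=O)(=O)c3cc(Cl)cc(Cl)c3)cnc3ccc(F)cc23)CC1`, gives 69%
- compound 3, `CC1CCN(c2c(S(=O)(=O)c3ccc(F)c(Cl)c3)cnc3cc(Cl)ccc23)CC1`, gives 94%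

For the measured compounds named here, compound 2 stands lowest of the three numbers measured so far. Going by the values given here, its nearest neighbour is compound 1, and the only step measured between two compounds differing in one place runs between them: a number 19 percentage points lower from compound 1 to compound 2 (beyond the scatter). Compound 3 sits higher still, but it differs from compound 2 in more than one place, so its value can only be read on its own.

Compound 4, `CC1CCN(c2c(S(=O)(=O)c3ccc(F)cc3)cnc3ccc(F)cc23)CC1`, keeps the core of compound 2 and alters the group on the sulfonyl sulfur: 4-fluorophenyl in place of 3,5-dichlorophenyl on a sulfonyl sulfur. Among the compounds with values here, no measured step touches this group, so the expectation rests on indirect grounds. Within the data shown here, the one step seen, from compound 1 to compound 2, shows that exchanging chloro for fluoro elsewhere lowered the read-out, and compound 4 gives up two chlorines for one fluorine. A further drop is therefore expected, a number 24 percentage points lower from compound 2 to compound 4 (beyond the scatter). Compound 4 is estimated at 45%, within a range from 20% to 70%.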

Compound 4, a percentage reported as inhibition, at one concentration (the size of the read-out at that concentration, not a potency): 87%
For compound 4 the middle estimate is 42 percentage points below the measured one, outside the stated range (above it).
By their numbers in this assay, from the lowest: compound 2; then compounds 4, 1 and 3 (each within the scatter of the next).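

Swapping the group on the sulfonyl sulfur moves the read-out in this assay: 4-fluorophenyl in place of 3,5-dichlorophenyl gives a number 18 percentage points higher from compound 2 to compound 4 (beyond the scatter) and shows that this position can change the number by itself. The earlier step, a number 19 percentage points lower from compound 1 to compound 2 (beyond the scatter), came from fluoro in place of chloro on an aromatic carbon elsewhere in the molecule, and its direction does not carry over to the sulfonyl aryl group. Nothing at hand explains the rise.

The change alters the number of halogens, their kind and where they sit all at once, so the compounds shown do not separate these parts. They also leave open how a plain phenyl or a 4-methoxyphenyl on the sulfonyl sulfur would read in this assay on the same core.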